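The source may hold more compounds than are shown below. What is called first, only, known or untested is meant among the compounds shown, and "the series" means these compounds.

Measured compounds:
compound 1 `COc1ccc(S(=O)(=O)N2CCc3cccc(-c4ccc(N)cc4)c32)cc1`: 162 nM
compound 2 `COc1ccc(S(=O)(=O)N2CCc3cccc(-c4ccco4)c32)cc1`: 42 nM
compound 3 `COc1ccc(S(=O)(=O)N2CCc3cccc(-c4ccc([N+](=O)[O-])cc4)c32)cc1`: 34 nM

All three have been measured in a functional assay on MKN-45 cells (Homo sapiens) for inhibition, with a stated time of 72 h; a lower number here means a stronger inhibitor, a higher number a weaker inhibitor. Among these numbers compound 1 stands highest: compound 2 is nearest, with a 3.9-fold lower number from compound 1 to compound 2 (0.59 log units; beyond the scatter), and compound 3 is furthest, with a 4.8-fold lower number from compound 1 to compound 3 (0.68 log units; beyond the scatter). Compound 2 and compound 3 are separated only by a 1.2-fold lower number from compound 2 to compound 3 (0.09 log units; within the scatter).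

Compound 4 `COc1ccc(S(=O)(=O)N2CCc3cccc(-c4cccc(F)c4)c32)cc1` has not yet been measured. Its difference from compound 1 is 3-fluorophenyl in place of 4-aminophenyl on an aromatic carbon.

Going by the values given here, two measured steps bear on this change, and both start from compound 1 and replace the 4-aminophenyl with another aromatic group: a 3.9-fold lower number from compound 1 to compound 2 (0.59 log units; beyond the scatter) and a 4.8-fold lower number from compound 1 to compound 3 (0.68 log units; beyond the scatter). Neither step introduces a 3-fluorophenyl, so the exact size of the step to compound 4 is uncertain, but both known steps point in the same direction and both lie beyond the scatter. Compound 4 is therefore expected to give a lower number than compound 1 in this assay, with an expected step of a 3.2-fold lower number from compound 1 to compound 4 (0.51 log units; beyond the scatter). The estimate for compound 4 is 50 nM, within a range from 20 nM to 130 nM.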

Compound 4, half-maximal inhibitory concentration: 84.7 nM
The estimate for compound 4 lay 1.7-fold (0.23 log units) below the measured number; low and high end bracket the measured number.
By their numbers in this assay, from the lowest: compounds 3, 2, 4 and 1 (each within the scatter of the next, the first and the last beyond it).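

In this assay, going by these compounds alone, the earlier compounds showed only steps beyond the scatter on leaving the 4-aminophenyl, whereas here, with a 1.9-fold lower number from compound 1 to compound 4 (0.28 log units; within the scatter), the 3-fluorophenyl cannot be told apart from the 4-aminophenyl it replaces, so not every replacement at this aromatic carbon gives such a step. The new compound also gives the first separation beyond the scatter among the groups that replace the 4-aminophenyl, with a 2.5-fold higher number from compound 3 to compound 4 (0.40 log units; beyond the scatter), while a 2.0-fold higher number from compound 2 to compound 4 (0.30 log units; within the scatter) leaves the 3-fluorophenyl and the furan-2-yl unresolved, so that compound 4 cannot be placed clearly against compound 1 or compound 2 but does stand apart from compound 3. Nothing available explains why these groups differ or fail to differ in this way.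

The 3-fluorophenyl differs from the 4-aminophenyl and the 4-nitrophenyl both in its substituent and in where that substituent sits on the phenyl ring, so the compounds shown cannot say which of the two matters. A plain phenyl ring, or a phenyl ring carrying a methoxy group or a carboxylic acid, would be needed to separate these two changes and to show how far the trend at this position extends.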